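Swapping Methoxy for Methyl in a Bile Acid Receptor Series

The compounds below may be only part of what the source reports. "The series", "measured", "known", "first", "only" and "open" are said of these compounds alone.

Compound 1, `Cc1ccccc1-n1nc(C)c2c1NC(=O)[C@H](C)S[C@@H]2c1ccc(-c2cccc(C(=O)O)c2)cc1`: "not active" (no number reported)
Compound 2, `COc1ccccc1-n1nc(C)c2c1NC(=O)[C@H](C)S[C@@H]2c1ccc(Oc2ccccc2)cc1`: 3300 nM

Of the compounds shown here, two sharing one core have been tested in an assay on isolated protein for agonist activity at Bile acid receptor (Homo sapiens), read by AlphaScreen, with a stated time of 30 min; a higher number here means that more compound is needed for the effect, a lower number that less compound is needed. In this assay compound 1 is recorded as "not active" (no number reported), so no number stands against it. In this assay compound 2 gives 3300 nM, which makes compound 2 the holder of the only number shown; compound 1 sits beside it as a single entry without a value, so the two cannot be set in order.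

Compound 3, `Cc1ccccc1-n1nc(C)c2c1NC(=O)[C@H](C)S[C@@H]2c1ccc(Oc2ccccc2)cc1`, has yet to be measured in this assay. It differs from compound 2 in one spot: methyl in place of methoxy on an aromatic carbon. Nothing in the measured pair shows how this change behaves on its own, since compound 1 differs from compound 2 in a second place as well. For the measured compounds named here, with no step between measured compounds to lean on, the expectation is a small step, most likely towards more compound being needed, of a size that could still fall inside the usual scatter. The estimated change from compound 2 to compound 3 is a 1.5-fold higher number from compound 2 to compound 3 (0.18 log units; within the scatter). Compound 3 is therefore expected to give about 5000 nM, within a range of 1500 nM to 15000 nM.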

Compound 3, half-maximal effective concentration: 1300 nM
Compound 3: middle estimate off by 3.8-fold (0.59 log units), on the high side; the whole stated range lies above it.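

In this assay, for the compounds shown here, going from 2-methoxyphenyl to 2-methylphenyl gives a 2.5-fold lower number from compound 2 to compound 3 (0.40 log units; beyond the scatter), and this is the first reading of this swap on its own, with everything else in the molecule unchanged. The step is modest but lies beyond the scatter, so this place on the aromatic ring, ortho to a large group, does respond to a small change, and the oxygen of the methoxy group is not required for a measurable number in this pair. Nothing measured here explains why the number falls, so the result stands as an observation only.

Compound 1 also carries the methyl group but has no number, so its difference from compound 3, which lies at the far end of the molecule, cannot be read as a step. The compounds shown also leave open whether the same ring position would accept a group such as chlorine, ethyl or an amine, and whether the swap from methoxy to methyl would give a similar step with a different group in place of the phenoxy ring.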